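This account rests on a few compounds, and the source may have more. Where it says the series, first, only, none or still open, it means among the compounds named here.

Measured in a functional assay on aorta (strain Wistar) for inhibition, with Thoracic aorta (Rattus norvegicus) as the target; a higher number here means a weaker inhibitor, a lower number a stronger inhibitor:
Compound 1, `COc1nc(-c2cc3ccccc3o2)cc(-c2ccccc2)c1C#N`, gives 232000 nM.
Compound 2, `CCOc1nc(-c2cc3ccccc3o2)cc(-c2ccccc2)c1C#N`, gives 310000 nM.
Compound 3, `CCOc1nc(-c2cc3ccccc3o2)cc(-c2ccc3ccccc3c2)c1C#N`, gives 423000 nM.

The three numbers sit close together. Among the measured compounds shown here, the step of a 1.3-fold higher number from compound 1 to compound 2 (0.13 log units; within the scatter) does not leave the usual scatter, and the two values of compound 1 and compound 3 also lie within the scatter of each other, so no compound can be set apart from the others on these numbers.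

Compound 4, `COc1nc(-c2cc3ccccc3o2)cc(-c2ccc(Cl)cc2)c1C#N`, has not yet been measured. It differs from compound 1 in one place: chloro in place of hydrogen on an aromatic carbon. Neither measured step makes the same change. The step of a 1.4-fold higher number from compound 2 to compound 3 (0.13 log units; within the scatter) alters the same phenyl ring, replacing it as a whole, and stays within the scatter; the step of a 1.3-fold higher number from compound 1 to compound 2 (0.13 log units; within the scatter) changes a different part of the shared core and also stays within the scatter. Nothing measured here suggests that a single chloro group on that ring should move this assay by more than the scatter in either direction.

Compound 4 is therefore expected to give about 250000 nM, with a likely range from 120000 nM to 520000 nM, which is a step of a 1.1-fold higher number from compound 1 to compound 4 (0.03 log units; within the scatter) that is expected to stay within the scatter.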

Compound 4, half-maximal inhibitory concentration: 286000 nM
Estimate against measurement, compound 4: 1.1-fold (0.06 log units) below; low and high end bracket the measured number.
By their numbers in this assay, from the lowest: compounds 1, 4, 2 and 3 (each within the scatter of the next).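

Among the compounds shown here, the new step, a 1.2-fold higher number from compound 1 to compound 4 (0.09 log units; within the scatter), is the first change in this assay that puts a single atom on the phenyl ring rather than replacing the ring as a whole. It shows that chloro can stand on this aromatic carbon, para to a large group, without taking the number out of the usual scatter, just as the larger change to naphthalen-2-yl did in a 1.4-fold higher number from compound 2 to compound 3 (0.13 log units; within the scatter). Nothing available here explains why this change has so little effect in this assay.

From the compounds shown here alone, compound 4 thus joins the other compounds in a group that cannot be told apart, so it remains open whether any change at this position can shift the number beyond the scatter. Going by these compounds, a single chloro group says little about how a very different group on the same carbon, such as an amine or a carboxylic acid, would behave, and so the reach of this tolerance remains unknown.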